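The source may hold more compounds than are shown below. What is called first, only, known or untested is meant among the compounds shown, and "the series" means these compounds.

In a functional assay on HeLa cells (Homo sapiens) for antiproliferative activity, read by MTT assay, with a stated time of 48 h (a higher number here means a weaker inhibitor of growth, a lower number a stronger inhibitor of growth), compound 1 `COC(=O)N1N=C(c2cccc(OC)c2)CC1c1cc(OC)c(OC)c(OC)c1` gives 1530 nM and compound 2 `COC(=O)N1N=C(c2cccc(O)c2)CC1c1cc(OC)c(OC)c(OC)c1` gives 1970 nM, while compound 3 `COC(=O)N1N=C(c2cc(OC)c(OC)c(OC)c2)CC1c1cc(OC)c(OC)c(OC)c1` has the highest number of the three, at 5680 nM. Compound 4 `COC(=O)N1N=C(c2ccc(OC)c(OC)c2)CC1c1cc(OC)c(OC)c(OC)c1` departs from compound 3 by hydrogen in place of methoxy on an aromatic carbon. Among the compounds with values here, the one measured step, a 1.3-fold higher number from compound 1 to compound 2 (0.11 log units; within the scatter), is a different change and offers little guidance. The closer guide carries fewer methoxy groups on the changed ring than compound 3, and this is compound 1, which gives 1530 nM. A modest move to a lower number is therefore expected. The expected step is a 2.0-fold lower number from compound 3 to compound 4 (0.31 log units; beyond the scatter). For compound 4 the estimate is 2800 nM, with an expected range of 1300 nM to 6000 nM.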

Compound 4, concentration for 50% growth inhibition: 3390 nM
Compound 4: the middle estimate sits 1.2-fold (0.08 log units) below what was measured; low and high end bracket the measured number.
By their numbers in this assay, from the lowest: compounds 1, 2, 4 and 3 (each within the scatter of the next, the first and the last beyond it).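

Methoxy in place of hydrogen on an aromatic carbon gives a 2.2-fold higher number from compound 1 to compound 4 (0.35 log units; beyond the scatter), the only new step beyond the scatter, and it is modest. By contrast, removing the methoxy group at this position gives a 1.7-fold lower number from compound 3 to compound 4 (0.22 log units; within the scatter), and 3,4-dimethoxyphenyl in place of 3-hydroxyphenyl gives a 1.7-fold higher number from compound 2 to compound 4 (0.24 log units; within the scatter), so in this assay neither change moves the number beyond the scatter. No measurement offered here accounts for these steps. The compounds shown leave open how an amine or a chlorine atom at this position would compare with methoxy and hydrogen.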